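Sulfonamide aryl swap: from compound 2 to compound 3

This account rests on a few compounds, and the source may have more. Where it says the series, first, only, none or still open, it means among the compounds named here.

Compound 1 `O=C1NCCN1c1ccc(S(=O)(=O)Nc2ccc(F)c(F)c2)cc1`: 620 nM
Compound 2 `Cc1ccc(NS(=O)(=O)c2ccc(N3CCNC3=O)cc2)c(C)c1`: 230 nM

Both values come from a functional assay on MCF7 cells (Homo sapiens) for antiproliferative activity, read by sulforhodamine B assay, with a stated time of 48 h; a higher number here means a weaker inhibitor, a lower number a stronger inhibitor. For the measured compounds named here, compound 2 stands at 230 nM, the lower of the two numbers so far, and compound 1 is its only neighbour. The next compound to be measured is compound 3 `COc1ccccc1NS(=O)(=O)c1ccc(N2CCNC2=O)cc1`, which carries 2-methoxyphenyl in place of 2,4-dimethylphenyl on a sulfonamide nitrogen.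

Going by the values given here, only one measured step bears on this change, and only indirectly. It is a 2.7-fold lower number from compound 1 to compound 2 (0.43 log units; beyond the scatter), a modest step made at the same sulfonamide nitrogen, with 2,4-dimethylphenyl in place of 3,4-difluorophenyl. Among the compounds with values here, no measured compound carries 2-methoxyphenyl, so the data give no direct reading for this group. Going by the size of that single step, a change at this place is expected to be modest at most, and a small move to a higher number in this assay seems the likelier outcome. The expected step is a 1.4-fold higher number from compound 2 to compound 3 (0.14 log units; within the scatter). For compound 3 the estimated value is 320 nM, with an expected range from 110 nM to 900 nM.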

Compound 3, half-maximal inhibitory concentration: 770 nM
Beside the measured number, compound 3's estimate is 2.4-fold (0.38 log units) below it; the range from low to high includes it.
By their numbers in this assay, from the lowest: compound 2; then compounds 1 and 3 (each within the scatter of the next).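

In this assay, moving to 2-methoxyphenyl at the sulfonamide nitrogen gives a 3.3-fold higher number from compound 2 to compound 3 (0.52 log units; beyond the scatter), so the lower number of compound 2 does not carry over to this other aryl group, even though both groups count 8 heavy atoms and differ by one hydrogen-bond acceptor. The comparison with 3,4-difluorophenyl gives a 1.2-fold higher number from compound 1 to compound 3 (0.09 log units; within the scatter), which places 2-methoxyphenyl level with that group and leaves 2,4-dimethylphenyl as the only one of the three aryl groups whose steps to both others lie beyond the scatter. Nothing available accounts for why this swap moves the number, and no measured property of these groups bears on it.

Still open, from the compounds shown here alone, is whether a single methyl group, as in 2-methylphenyl or 4-methylphenyl, would be enough to keep the number of compound 2, and whether plain phenyl would sit with compound 2 or with compounds 1 and 3. Also open, going by these compounds, is how this position responds to groups of a different kind, such as an aryl group bearing an amine or a carboxylic acid.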